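This account rests on a few compounds, and the source may have more. Where it says the series, first, only, none or still open, it means among the compounds named here.

Measured so far in an assay on isolated protein for inhibition of Dihydrofolate reductase (Mus musculus); on this read-out lower numbers stand for lower potency and higher numbers for higher potency (the scale is a negative logarithm):

Compound 1, `CC1(C)N=C(N)N=C(N)N1c1ccc(CCCCc2ccccc2)c(Cl)c1`, gives 7.92.
Compound 2, `CN(C)C(=O)c1cccc(NC(=O)NCc2cccc(N3C(N)=NC(N)=NC3(C)C)c2)c1`, gives 7.77.
Compound 3, `CC1(C)N=C(N)N=C(N)N1c1cccc(CNC(=O)Nc2cccc(Cl)c2)c1`, gives 8.05.

For the measured compounds named here, compound 3 has the highest of the three numbers, yet it sits within the scatter of both neighbours: compound 1 lies close below it, and the single measured step, a number 0.28 log units higher from compound 2 to compound 3 (within the scatter), is also within the scatter. So far, then, swapping the group on the outer aromatic ring has not moved the read-out beyond what repeated measurements would show on their own.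

Compound 4, `CC1(C)N=C(N)N=C(N)N1c1cccc(CNC(=O)Nc2cccc([N+](=O)[O-])c2)c1`, has not yet been measured. It differs from compound 3 in one place: nitro in place of chloro on an aromatic carbon. Going by the values given here, no measured step involves a nitro group, so the only guide is that the earlier swap at this same position, from dimethylcarbamoyl to chloro, left the read-out essentially unchanged.

The step of a number 0.05 log units lower from compound 3 to compound 4 (within the scatter) is therefore expected to stay within the scatter. Compound 4 is expected to give about 8, with a likely range from 7.5 to 8.5.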

Compound 4, logarithm of the reciprocal of the active concentration, log(1/C): 8.1
The estimate for compound 4 lay 0.10 log units below the measured number; the range from low to high includes it.
By their numbers in this assay, from the lowest: compounds 2, 1, 3 and 4 (each within the scatter of the next, the first and the last beyond it).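

In this assay, the change at this position gives a number 0.05 log units higher from compound 3 to compound 4 (within the scatter) even though nitro, with its 3 heavy atoms and 2 hydrogen-bond acceptors, replaces a single chlorine with none. Chloro and nitro therefore cannot be told apart here. For the compounds shown here, the position also now shows its only step beyond the scatter, a number 0.33 log units higher from compound 2 to compound 4 (beyond the scatter) and modest in size, so the swap from dimethylcarbamoyl to nitro has a measurable, though small, effect, while the swap from dimethylcarbamoyl to chloro does not. No measurement shown explains these results.

Only three groups at this one place on the ring are shown, so it remains open whether an amine or a carboxylic acid would stay level with chloro and nitro. Also open, from the compounds shown here alone, is how a hydrogen, with no group at all, would read.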